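This account rests on a few compounds, and the source may have more. Where it says the series, first, only, none or still open, it means among the compounds named here.

Measured in an assay on isolated protein for binding affinity to 5-hydroxytryptamine receptor 3A (Homo sapiens); a higher number here means a weaker inhibitor, a lower number a stronger inhibitor:
compound 1 `CS(=O)(=O)N1CCN(CC(O)CN2CCC(CNC(=O)c3cccc4[nH]cnc34)CC2)CC1` gives 50100 nM
compound 2 `CS(=O)(=O)N1CCN(CC(O)CN2CCC(NC(=O)c3cccc4[nH]cnc34)CC2)CC1` gives 63100 nM
compound 3 `COC(=O)N1CCN(CCN2CCC(CNC(=O)c3cccc4[nH]c(C(C)C)nc34)CC2)CC1` gives 79400 nM

Compound 3 has the highest of the three numbers, but its gaps to compound 2 and to compound 1 both lie within the scatter, so the three read as one weak level. Compound 4 `CC(=O)N1CCC(CN2CCC(CNC(=O)c3cccc4[nH]c(C(C)C)nc34)CC2)CC1` differs from compound 3 by 1-acetylpiperidin-4-yl in place of (4-(methoxycarbonyl)piperazin-1-yl)methyl on a saturated chain carbon bound to an amine nitrogen in a ring. For the measured compounds named here, no measured pair isolates this change, so nothing here points to a direction for it. The expectation is that a 1.1-fold lower number from compound 3 to compound 4 (0.05 log units; within the scatter) stays within the scatter, in either direction. Compound 4 is estimated in this assay at 70000 nM, with an expected range from 25000 nM to 200000 nM. Because compound 3 already sits at 79400 nM, compound 4 is expected to remain in the same weak region.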

Compound 4, inhibition constant: 100000 nM
Beside the measured number, compound 4's estimate is 1.4-fold (0.15 log units) below it; low and high end bracket the measured number.
By their numbers in this assay, from the lowest: compounds 1, 2, 3 and 4 (each within the scatter of the next).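

In this assay, 1-acetylpiperidin-4-yl in place of (4-(methoxycarbonyl)piperazin-1-yl)methyl on a saturated chain carbon bound to an amine nitrogen in a ring gives a 1.3-fold higher number from compound 3 to compound 4 (0.10 log units; within the scatter). For the compounds shown here, this is the first pair that differs in one place, and the position tolerates this exchange of one six-membered non-aromatic ring for another with no change beyond the scatter, all at the same weak level. No evidence on a cause accompanies this result.

Still open, on these data alone, is whether any group on this chain carbon leaves that weak level. A carboxylic acid or a phenyl ring there would be a markedly different test of the position.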